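One more methoxy on compound 2

A few compounds are considered here, and "the series" means these few. Any claim that something is new, unique, unknown or untested is made for them only; others in the source may bear on it.

Measured so far in a functional assay on the whole organism (strain Kunming) with Mus musculus as the target, in the formalin test, with a stated time of 0.5 h; a higher number here means that more compound is needed for the effect, a lower number that less compound is needed
Compound 1 `COc1ccccc1/C=C/C(=O)OC/C=C/c1cc(OC)c(OC)cc1OC` gives 294 umol/kg
Compound 2 `COc1cc(OC)c(OC)cc1/C=C/COC(=O)/C=C/c1ccc(OC)c(OC)c1` gives 225 umol/kg
Compound 3 `COc1cc(OC)c(OC)cc1/C=C/COC(=O)/C=C/c1cc(OC)c(OC)c(OC)c1` gives 192 umol/kg

These three numbers lie close together, and compound 2 has no gap beyond the scatter on either side. Its nearest neighbour is compound 3 and its furthest is compound 1, and both gaps are small.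

The next compound is compound 4 `COc1cc(OC)c(OC)cc1/C=C/COC(=O)/C=C/c1ccc(OC)c(OC)c1OC` and it differs from compound 2 by a single change methoxy in place of hydrogen on an aromatic carbon which in words is methoxy in place of hydrogen on an aromatic carbon. Going by the values given here, the closest precedent is a 1.2-fold lower number from compound 2 to compound 3 (0.07 log units; within the scatter) since this is the same kind of change, though not at the same place. The other measured step is a 1.3-fold lower number from compound 1 to compound 2 (0.12 log units; within the scatter) and it also alters the methoxy groups on that aromatic ring. Both steps stayed within the scatter, so neither offers grounds for a large move. Among the compounds with values here, the data hold no measured compound with a methoxy at the new place of compound 4, which leaves the range wide.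

The expected result is a 1.1-fold lower number from compound 2 to compound 4 (0.05 log units; within the scatter) with no shift beyond the scatter anticipated. Compound 4 is estimated at 200 umol/kg in this assay with an expected range of 105 umol/kg to 370 umol/kg for its measurement.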

Compound 4, dose for half-maximal effect: 176 umol/kg
Compound 4: middle estimate off by 1.1-fold (0.06 log units), on the high side, within the range that was stated.
By their numbers in this assay, from the lowest: compounds 4, 3, 2 and 1 (each within the scatter of the next).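

In this assay the added methoxy of compound 4 sits on an aromatic carbon ortho to a large group, ortho to a methoxy group and meta to a methoxy group, and this change gives a 1.3-fold lower number from compound 2 to compound 4 (0.11 log units; within the scatter) on that ring. The earlier compounds shown here showed the same change only at another place, with a 1.2-fold lower number from compound 2 to compound 3 (0.07 log units; within the scatter) as its result, so methoxy in place of hydrogen has now stayed within the scatter at two places on this ring. Among the compounds shown, therefore, neither place stands apart from compound 2, and no measured evidence bears on why this step is small.

As far as these compounds go, what remains open is whether a group other than methoxy at this place, such as a hydroxyl, an amine or a carboxylic acid, would move the number beyond the scatter. All four compounds carry only methoxy groups on their aromatic rings and share the same ester link, so these compounds also cannot say what an amide in place of that ester or a longer chain would do.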